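Notes on the aryl series: 2-methylphenyl to 4-fluorophenyl

The source may hold more compounds than are shown below. What is called first, only, known or untested is meant among the compounds shown, and "the series" means these compounds.

- compound 1 `C[C@H]1CC[C@@H]2[C@@H](OC(=O)[C@]23CC(c2c(Cl)cccc2Cl)=NO3)[C@]2(C)C(=O)C=C[C@@]12O`: 56000 nM
- compound 2 `C[C@H]1CC[C@@H]2[C@@H](OC(=O)[C@]23CC(c2ccc([N+](=O)[O-])cc2)=NO3)[C@]2(C)C(=O)C=C[C@@]12O`: 12000 nM
- compound 3 `Cc1ccccc1C1=NO[C@]2(C1)C(=O)O[C@@H]1[C@H]2CC[C@H](C)[C@]2(O)C=CC(=O)[C@@]12C`: 10000 nM

All three values come from a functional assay on PC-3 cells (Homo sapiens) for cytotoxicity, read by sulforhodamine B assay, with a stated time of 48 h (a lower number here means a stronger inhibitor, a higher number a weaker inhibitor), and only the aryl group varies. Compound 3 shares the low end of the three numbers with compound 2, and a 1.2-fold lower number from compound 2 to compound 3 (0.08 log units; within the scatter) gives no separation between them. Compound 1 stands apart, as shown by a 4.7-fold lower number from compound 1 to compound 2 (0.67 log units; beyond the scatter) and a 5.6-fold lower number from compound 1 to compound 3 (0.75 log units; beyond the scatter).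

Compound 4 `C[C@H]1CC[C@@H]2[C@@H](OC(=O)[C@]23CC(c2ccc(F)cc2)=NO3)[C@]2(C)C(=O)C=C[C@@]12O` is unmeasured. It carries 4-fluorophenyl in place of 2-methylphenyl on a carbon with a double bond to nitrogen.

Within the data shown here, no measured compound carries fluorine, so the evidence is indirect. The closest guide is a 1.2-fold lower number from compound 2 to compound 3 (0.08 log units; within the scatter), an exchange of one aryl group for another that left the number within the scatter. The larger steps both start from the 2,6-dichlorophenyl group of compound 1, which compound 4 lacks. The expected step is a 1.2-fold higher number from compound 3 to compound 4 (0.08 log units; within the scatter) in this assay, which means none beyond the scatter. The estimated value for compound 4 is 12000 nM, with an expected range of 5000 nM to 30000 nM.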

Compound 4, half-maximal inhibitory concentration: 27000 nM
Compound 4: middle estimate off by 2.3-fold (0.35 log units), on the low side; measured number inside the range.
By their numbers in this assay, from the lowest: compounds 3 and 2 (each within the scatter of the next); then compound 4; then compound 1.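

In this assay, the aryl group on the carbon with a double bond to nitrogen can move the number even when 2,6-dichlorophenyl is not involved: a 2.7-fold higher number from compound 3 to compound 4 (0.43 log units; beyond the scatter) and a 2.3-fold higher number from compound 2 to compound 4 (0.35 log units; beyond the scatter) both lie beyond the scatter, unlike the earlier exchange between compound 2 and compound 3. The 4-fluorophenyl group also stays apart from 2,6-dichlorophenyl, with a 2.1-fold lower number from compound 1 to compound 4 (0.32 log units; beyond the scatter), so compound 4 takes a separate middle place in the order. No measurement available here accounts for these steps.

Open, from the compounds shown here alone, is how a plain phenyl group, without any substituent, would sit against these four aryl groups. Also open, going by these compounds, is whether an aryl group carrying an amine or a carboxylic acid, or a longer alkyl chain in place of the aryl group, would stay within this range.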